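The source may report more compounds than this note shows. Statements on the series, on what has been measured and on what is new or still open speak of the compounds shown alone.

Compound 1 `COc1ccc2nccc(C3CN(C4CCN(Cc5c[nH]c6ccccc56)CC4)C(=O)O3)c2c1`: in an in vitro functional assay on RBL cells for antagonist activity at C-C chemokine receptor type 8 (Homo sapiens), read by FLIPR and calcium flux (on this read-out lower numbers stand for stronger inhibition and higher numbers for weaker inhibition), compound 1 gives < 50200 nM, a limit of the assay.
Compound 2 `COc1ccc2nccc(C3CN(C4CCN(CCCc5ccccc5)CC4)C(=O)O3)c2c1`: in this assay compound 2 gives 251 nM.
Compound 3 `COc1ccc2nccc(C3CN(C4CCN(Cc5ccccc5Cl)CC4)C(=O)O3)c2c1`: in this assay compound 3 gives < 50200 nM, again a limit.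

Compound 3 thus stands only at a limit in this assay, the one at which two of the three values sit (the limit of < 50200 nM in this assay, at which 2 of the 3 values shown sit). Compound 4 `COc1ccc2nccc(C3CN(C4CCN(Cc5ccc(C#N)cc5)CC4)C(=O)O3)c2c1` differs from compound 3 by 4-cyanophenyl in place of 2-chlorophenyl on a saturated chain carbon bound to an amine nitrogen in a ring. Among the measured compounds shown here, the steps touching compound 3, a step that the two limits leave unreadable from compound 1 to compound 3 and a step that the limit leaves unreadable from compound 2 to compound 3, are unreadable in size, and no measured step sets a 2-chlorophenyl against a 4-cyanophenyl at this position. For the measured compounds named here, the expectation for compound 4 therefore rests on the limit of compound 3 and the single reading of compound 2, with the step that the limit leaves unreadable from compound 3 to compound 4 expected to be of uncertain direction. Compound 4 is estimated at 5000 nM, between 400 nM and 50000 nM, with a fair chance that only a limit is reported.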

Compound 4, half-maximal inhibitory concentration: 12600 nM
Compound 4: the middle estimate sits 2.5-fold (0.40 log units) below what was measured, within the range that was stated.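

In this assay, the change to 4-cyanophenyl in place of phenethyl gives a 50-fold higher number from compound 2 to compound 4 (1.70 log units; beyond the scatter), the first size that can be read at this position. Compound 4 also shows that a group bearing a nitrile on this saturated chain carbon can give a number and not only a limit. The steps from compound 1 and compound 3 to compound 4 cannot be read, and those two compounds stand only at a limit: the limit of < 50200 nM in this assay, at which 2 of the 4 values shown sit.

On these data alone, whether a longer chain ending in 4-cyanophenyl would keep the reading of compound 2 stays open. So does the effect of an amine in place of the nitrile.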